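Trading a decyl chain for a trimethoxyphenyl ring

The compounds below may be only part of what the source reports. "The series", "measured", "known", "first", "only" and "open" are said of these compounds alone.

Of the compounds shown here, three share a trifluoromethyl-bearing core and have been tested in a functional assay on MDA-MB-231 cells (Homo sapiens) for antiproliferative activity, read by sulforhodamine B assay, with a stated time of 48 h; a lower number here means a stronger inhibitor of growth, a higher number a weaker inhibitor of growth. Compound 1 `CCCCCCCCCCn1cc(Cn2c(-c3ccco3)nc3nc(C(F)(F)F)ccc3c2=O)nn1` gives 1100 nM in this assay, compound 2 `CCc1nc2nc(C(F)(F)F)ccc2c(=O)n1Cc1cn(CCC(F)(F)C(F)(F)C(F)(F)C(F)(F)C(F)(F)C(F)(F)F)nn1` gives 2830 nM, and compound 3 `CCCCCCCCCCn1cc(COc2nc(-c3ccccc3)nc3nc(C(F)(F)F)ccc23)nn1` gives 1050 nM. Compound 3 has the lowest of the three numbers; its gap to compound 1 is within the scatter, while its gap to compound 2 lies beyond it.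

Compound 4 `COc1cc(-n2cc(COc3nc(-c4ccccc4)nc4nc(C(F)(F)F)ccc34)nn2)cc(OC)c1OC` is not yet measured. It differs from compound 3 by 3,4,5-trimethoxyphenyl in place of decyl on an aromatic nitrogen. For the measured compounds named here, no measured pair shows this change, so the direction is uncertain; the step from compound 3 to compound 4 is expected to be small, a 1.5-fold lower number from compound 3 to compound 4 (0.18 log units; within the scatter), toward a slightly lower number. Compound 4 is estimated to give 700 nM, in the range 200 nM to 3000 nM.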

Compound 4, concentration for 50% growth inhibition: 240 nM
The estimate for compound 4 lay 2.9-fold (0.46 log units) above the measured number, within the range that was stated.
By their numbers in this assay, from the lowest: compound 4; then compounds 3 and 1 (each within the scatter of the next); then compound 2.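

For the compounds shown here, replacing decyl with 3,4,5-trimethoxyphenyl on the aromatic nitrogen gives a 4.4-fold lower number from compound 3 to compound 4 (0.64 log units; beyond the scatter) in this assay and is the first change at this position whose size can be read. For this pair, a long alkyl chain on that nitrogen is not needed for growth inhibition, and an aromatic ring carrying methoxy groups gives the lower number. Nothing available explains the step in terms of either group.

Going by these compounds, it remains open whether the ring itself or its methoxy groups account for the step, as an unsubstituted phenyl on this nitrogen would show. On these data alone, whether the same exchange holds on the core of compound 1 also remains open.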